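The source may report more compounds than this note shows. Statements on the series, on what has been measured and on what is new or still open speak of the compounds shown alone.

Measured so far in a functional assay on KB cells (Homo sapiens) for inhibition, read by sulforhodamine B assay; on this read-out lower numbers stand for stronger inhibition of growth and higher numbers for weaker inhibition of growth:
Compound 1 `COc1cc(-c2ccc(-c3ccc(-c4nc5cc(C)ccc5[nH]4)cc3)cc2)cc(OC)c1OC`: 2110 nM
Compound 2 `COc1ccc(-c2ccc(-c3ccc(-c4nc5ccccc5[nH]4)cc3)cc2)cc1OC`: 9250 nM
Not yet measured:
Compound 3 `COc1cc(-c2ccc(-c3ccc(-c4nc5ccccc5[nH]4)cc3)cc2)cc(OC)c1OC`

Compound 2 stands highest of the two numbers at 9250 nM, and compound 1 lies lower, beyond the scatter. Compound 3 follows from compound 2 with methoxy in place of hydrogen on an aromatic carbon. Differing from compound 3 in one further place but also carrying this methoxy, compound 1 gives 2110 nM. On that value, a moderate downward step beyond the scatter is expected in this assay. The expected step is a 2.6-fold lower number from compound 2 to compound 3 (0.42 log units; beyond the scatter). For compound 3 the estimated value is 3500 nM, with an expected range from 1200 nM to 9000 nM.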

Compound 3, concentration for 50% growth inhibition: 2980 nM
For compound 3 the middle estimate is 1.2-fold (0.07 log units) above the measured one; low and high end bracket the measured number.
By their numbers in this assay, from the lowest: compounds 1 and 3 (each within the scatter of the next); then compound 2.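

In this assay, methoxy in place of hydrogen on an aromatic carbon, ortho to a methoxy group and meta to a large group, gives a 3.1-fold lower number from compound 2 to compound 3 (0.49 log units; beyond the scatter) as a modest step at this position. Hydrogen in place of methyl on an aromatic carbon gives a 1.4-fold higher number from compound 1 to compound 3 (0.15 log units; within the scatter), so this methyl change cannot be told from the scatter. Nothing at hand explains either step. 

As far as these compounds go, whether a hydroxyl or an ethoxy group at the methoxy position would give a similar step remains open, as does whether a chlorine atom in place of the methyl would differ from compound 3.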